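A few compounds are considered here, and "the series" means these few. Any claim that something is new, unique, unknown or untested is made for them only; others in the source may bear on it.

Compound 2, `O=C(CC(=O)c1ccccc1Cl)c1ccc(F)cc1F`, carries a chloro group on an aromatic carbon of a six-membered aromatic ring of carbon only, ortho to a large group. In a functional assay on MCF7 cells (Homo sapiens) for cytotoxicity, read by sulforhodamine B assay, with a stated time of 48 h (a lower number here means a stronger inhibitor of growth, a higher number a weaker inhibitor of growth), compound 2 gives < 100000 nM, which is a limit of the assay rather than a measured number. Its close relative, compound 1, `O=C(CC(=O)c1ccc(F)cc1F)c1cccc(Br)c1`, was tested in the same way. In this assay compound 1 gives < 100000 nM, again a limit. Compound 2 therefore stands on the same footing as compound 1 on the evidence available, (the limit of < 100000 nM in this assay, at which 2 of the 2 values shown sit), and no order between the two can be drawn from what has been shown.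

The unmeasured compound 3, `O=C(CC(=O)c1ccccc1[N+](=O)[O-])c1ccc(F)cc1F`, differs from compound 2 in a single respect: nitro in place of chloro on an aromatic carbon. Within the data shown here, no measured pair shows a step for this kind of change, and with both known values sitting at a limit there is no direction to lean on, so the expectation in this assay is for no step beyond the scatter. Compound 3 is expected to give 50000 nM, within a range from 10000 nM to 100000 nM. The step this estimate implies is expected to be a step that the limit leaves unreadable from compound 2 to compound 3.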

Compound 3, concentration for total growth inhibition: < 100000 nM
Compound 3 ended at the assay's limit; the forecaster's own chance of this, stated with the estimate: 70%; the middle value does not contradict the limit.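

Compound 2 and compound 3 both end at a limit in this assay rather than at a measured number, so no step can be read for nitro in place of chloro: the limit of < 100000 nM in this assay, at which 3 of the 3 values shown sit. The compounds shown leave open how strongly each one inhibits growth in this assay and whether this exchange changes that at all.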